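A few compounds are considered here, and "the series" means these few. Any claim that something is new, unique, unknown or untested is made for them only; others in the source may bear on it.

Of the compounds shown here, two built on a shared core have so far been tested in a functional assay for inhibition, with Homo sapiens as the target; on this read-out higher numbers stand for weaker inhibition and lower numbers for stronger inhibition. For compound 1 `CN(c1ccccc1)c1nccc(-c2ccncc2)n1` the assay reports no number, only a limit, > 24000 nM, meaning the read-out stopped at the edge of what the test can resolve. Compound 2 `NS(=O)(=O)c1ccc(Nc2nccc(-c3ccncc3)n2)cc1`, in this assay, gives 5100 nM. For the measured compounds named here, that makes compound 2 the holder of the only actual number among the results; the other result sits at the assay limit (the limit of > 24000 nM in this assay, at which 1 of the 2 values shown sits). Compound 1 and compound 2 differ in more than one place, so no single change can be read from the pair.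

Compound 3 `c1ccc(Nc2nccc(-c3ccncc3)n2)cc1` moves one step from compound 2: hydrogen in place of sulfamoyl on an aromatic carbon. Going by the values given here, no measured pair shows this change on its own, so its size is open. Compound 3 is expected to show weaker inhibition than compound 2, given the value of 5100 nM for compound 2 and the chance that removing the sulfamoyl raises the read-out. The expected step from compound 2 to compound 3 is a 2.9-fold higher number from compound 2 to compound 3 (0.47 log units; beyond the scatter). Compound 3 is estimated at 15000 nM, with a range from 5000 nM to 45000 nM.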

Compound 3, half-maximal inhibitory concentration: 900 nM
For compound 3 the middle estimate is 17-fold (1.22 log units) above the measured one; the measured number lies below the stated range.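

For the compounds shown here, the first pair that differs in one place shows that the sulfamoyl, on an aromatic carbon para to a large group, is not needed for inhibition in this assay: with a plain hydrogen there, the step is a 5.7-fold lower number from compound 2 to compound 3 (0.75 log units; beyond the scatter), so the simpler compound 3 is the stronger inhibitor of the two. Compound 3 also links to compound 1 through a single change at another place, the nitrogen on an aromatic ring, where hydrogen in place of methyl gives an at least 26-fold lower number from compound 1 to compound 3 (1.42 log units; beyond the scatter), so this one methyl separates a clear read-out from none. The result for compound 1 is a limit and not a number, which leaves the true size of that second step open: the limit of > 24000 nM in this assay, at which 1 of the 3 values shown sits.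

At the aromatic carbon, only sulfamoyl and hydrogen are shown, so it remains open whether a different group there, such as an amine or a carboxylic acid, would strengthen or weaken inhibition relative to compound 3. On the nitrogen, only methyl and hydrogen are shown, and nothing yet tells how a longer chain such as ethyl would fare.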